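The source may report more compounds than this note shows. Statements on the series, on what has been measured and on what is new or still open speak of the compounds shown alone.

Of the compounds shown here, three sharing one core have been tested in a functional assay on NCI/ADR-RES cells (Homo sapiens) for inhibition, read by sulforhodamine B assay, with a stated time of 48 h; a higher number here means a weaker inhibitor of growth, a lower number a stronger inhibitor of growth. Compound 1 `O=C(Nc1cccc(-n2cc(-c3ccncc3)c(-c3ccc(Cl)c(O)c3)n2)c1)Nc1ccc(Cl)c(Cl)c1` gives only a limit in this assay, > 32500 nM, and not a number. Compound 2 `O=C(Nc1cccc(-n2cc(-c3ccncc3)c(-c3ccc(Cl)c(O)c3)n2)c1)Nc1cc(C(F)(F)F)cc(C(F)(F)F)c1` in this assay gives 5250 nM. Compound 3 `COc1cc(-c2nn(-c3cccc(NC(=O)Nc4cccc(C(F)(F)F)c4)c3)cc2-c2ccncc2)ccc1Cl` in this assay gives 3640 nM, the lowest of the two numbers shown, though compound 2 sits within the usual scatter of it, so the two cannot be ranked against each other.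

The compound not yet measured, compound 4 `O=C(Nc1cccc(-n2cc(-c3ccncc3)c(-c3ccc(Cl)c(O)c3)n2)c1)Nc1cccc(C(F)(F)F)c1`, differs from compound 3 in a single spot: hydrogen in place of methyl on an oxygen on an aromatic ring. The hydroxy that enters is the same group that compound 1 and compound 2 already carry on that ring, while compound 3 is the only one of the three with a methoxy there.

For the measured compounds named here, no measured pair isolates this exchange, so its effect can only be judged indirectly. The step of a 1.1-fold higher number from compound 3 to compound 4 (0.04 log units; within the scatter) is expected to be small, within the scatter rather than beyond it, because compound 2 with the hydroxy already in place gives 5250 nM. Compound 4 is therefore expected to give about 4000 nM in this assay, with a range from 1500 nM to 12000 nM.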

Compound 4, concentration for total growth inhibition: > 32500 nM
Compound 4: a limit, no number (the forecaster's own chance of this, stated with the estimate: 5%); middle value at least 8.1-fold (0.90 log units) from the limit.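

In this assay, for the compounds shown here, replacing methoxy with hydroxy on the 4-chloro-3-methoxyphenyl group brings an at least 8.9-fold higher number from compound 3 to compound 4 (0.95 log units; beyond the scatter), so this oxygen is a place where a single methyl can separate a measurable value from none, a change that no earlier pair could isolate. The hydroxy alone does not settle the outcome, since compound 2 carries it too and gives a measurable value, while losing one trifluoromethyl brings an at least 6.1-fold higher number from compound 2 to compound 4 (0.79 log units; beyond the scatter). Compound 4 gives a limit and not a number, so both steps are minimum sizes, and its step from compound 1, which also gives a limit, cannot be read: the limit of > 32500 nM in this assay, at which 2 of the 4 values shown sit.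

From the compounds shown here alone, how far compound 4 and compound 1 truly lie past that limit remains open, and with it any ranking of the two. Also open, going by these compounds, is whether methoxy would bring a similar step with the two trifluoromethyl groups of compound 2 in place, and what an ethoxy or an amine would give in place of the hydroxy.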